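This account rests on a few compounds, and the source may have more. Where it says the series, first, only, none or still open, it means among the compounds named here.

Compound 1 `COc1cc(-c2nn(-c3cccc(NC(=O)c4cccc(C(F)(F)F)c4)c3)cc2-c2ccncc2)ccc1Cl` and compound 2 `COc1cc(-c2nn(-c3cccc(NC(=O)Nc4cccc(C(F)(F)F)c4)c3)cc2-c2ccncc2)ccc1Cl` share one core and differ only at the carbonyl carbon. In a functional assay on MDA-MB-468 cells (Homo sapiens) for inhibition, read by sulforhodamine B assay, with a stated time of 48 h (a lower number here means a stronger inhibitor, a higher number a weaker inhibitor), compound 1 gives 1320 nM, and compound 2 gives 600 nM. For the measured compounds named here, the one step among the measured pair, a 2.2-fold lower number from compound 1 to compound 2 (0.34 log units; beyond the scatter), is modest but beyond the scatter. Going by the values given here, compound 2 thus stands at the lowest of the two numbers, with compound 1 its only neighbour.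

Compound 3 `COc1cc(-c2nn(-c3cccc(NC(=O)c4ccc(Cl)c(C(F)(F)F)c4)c3)cc2-c2ccncc2)ccc1Cl` is formed from compound 2 by 4-chloro-3-(trifluoromethyl)phenyl in place of (3-(trifluoromethyl)phenyl)amino on a carbonyl carbon. Among the compounds with values here, this change undoes the amide-to-urea step seen between compound 1 and compound 2 and adds a chlorine, for which no measured step exists. Within the data shown here, the only bearing step is a 2.2-fold lower number from compound 1 to compound 2 (0.34 log units; beyond the scatter), so a return toward the number of compound 1 is the expectation in this assay; the chlorine contributes an unknown shift. Compound 3 is therefore estimated at 1000 nM, between 400 nM and 2500 nM, an expected step of a 1.7-fold higher number from compound 2 to compound 3 (0.22 log units; within the scatter).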

Compound 3, half-maximal inhibitory concentration: 3690 nM
For compound 3 the middle estimate is 3.7-fold (0.57 log units) below the measured one; measured number above the stated range.
By their numbers in this assay, from the lowest: compound 2; then compound 1; then compound 3.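

In this assay, chloro in place of hydrogen on an aromatic carbon of the amide series gives a 2.8-fold higher number from compound 1 to compound 3 (0.45 log units; beyond the scatter) and so shows, as the earlier pair could not, that this ring responds to a substituent and that here the response is a weaker number. The full exchange of (3-(trifluoromethyl)phenyl)amino for 4-chloro-3-(trifluoromethyl)phenyl on the carbonyl carbon gives a 6.2-fold higher number from compound 2 to compound 3 (0.79 log units; beyond the scatter) and is the widest step seen so far, with the loss of the urea nitrogen and the gain of chlorine joined in one change. Nothing measured here accounts for either step.

The compounds shown leave open how the chlorine would act on the urea of compound 2. From the compounds shown here alone, whether a fluorine, a methyl or a methoxy group in place of that chlorine would move the number the same way also remains unknown.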